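Cyclopropyl to isopropyl on the aryl nitrogen side chain

A few compounds are considered here, and "the series" means these few. Any claim that something is new, unique, unknown or untested is made for them only; others in the source may bear on it.

Measured so far, in a physicochemical assay for lipophilicity, read by LC-MS, in phosphate buffer, measured as octanol-water partition, at pH 7.4; a lower number here means a more polar compound, a higher number a more lipophilic compound:
- compound 1 `COc1cc(N(CC2CC2)c2ccc(F)c3ccccc23)cnc1C(=O)[C@H]1C[C@@H]1C(=O)O`: 1.9
- compound 2 `COc1cc(N(CC(C)C)c2ccc(F)c3ccccc23)cnc1C(=O)[C@H]1C[C@@H]1C(=O)O`: 2.2
- compound 3 `COc1cc(N(CC2CC2)c2cc(Cl)c(F)cc2F)cnc1C(=O)[C@H]1C[C@@H]1C(=O)O`: 1.1

Compound 1 and compound 2 share one core and differ only in the side chain on the aryl nitrogen: isopropyl in place of cyclopropyl on a saturated chain carbon bound to a nitrogen on an aromatic ring. That change gave a number 0.30 log units higher from compound 1 to compound 2 (within the scatter), so the two values are read as equal within the usual spread of this assay.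

Compound 3 carries a different core; how it differs from compound 1 is not broken down here. In this assay compound 3 stands lowest of the three, and its gap to compound 1 and to compound 2 lies beyond the scatter in both cases.

Compound 4 `COc1cc(N(CC(C)C)c2cc(Cl)c(F)cc2F)cnc1C(=O)[C@H]1C[C@@H]1C(=O)O` is not yet measured. It relates to compound 3 as compound 2 relates to compound 1, since isopropyl in place of cyclopropyl on a saturated chain carbon bound to a nitrogen on an aromatic ring is the same change at the same place. Among the measured compounds shown here, the expectation for compound 4 therefore rests on the pair already measured: the step from compound 3 to compound 4 is estimated at a number 0.30 log units higher from compound 3 to compound 4 (within the scatter), matching in size the step from compound 1 to compound 2, because a number 0.30 log units higher from compound 1 to compound 2 (within the scatter) is the only measured instance of this change. Compound 4 is accordingly estimated at 1.4, with a likely range from 1.1 to 1.7.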

Compound 4, distribution coefficient: 1.3
Compound 4: middle estimate off by 0.10 log units, on the high side; measured number inside the range.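

In this assay the swap of cyclopropyl for isopropyl on a saturated chain carbon bound to a nitrogen on an aromatic ring gives a number 0.20 log units higher from compound 3 to compound 4 (within the scatter) on the core of compound 3 and gives a number 0.30 log units higher from compound 1 to compound 2 (within the scatter) on the core of compound 1 as the earlier instance, so on both cores the step stays within the scatter and the swap carries from one core to the other without a step that can be told from repeat spread. This does not show that the swap shifts the read-out at all, nor that the two cores respond alike or differently, and two pairs on two cores make no rule for any further core in the series. No data shown here offer an explanation for either step.

The compounds shown leave open what this assay would read for a side chain outside the cyclopropylmethyl and isobutyl pair, such as a longer chain like n-pentyl, or a chain ending in a hydroxyl group or an amine, at the same place. They also leave open whether the swap stays this small on a core other than those of compound 1 and compound 3.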